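This account rests on a few compounds, and the source may have more. Where it says the series, first, only, none or still open, it means among the compounds named here.

Measured so far in a functional assay on HL-60 cells (Homo sapiens) for cytotoxicity, read by MTT assay, with a stated time of 72 h; on this read-out higher numbers stand for weaker inhibition and lower numbers for stronger inhibition:
Compound 1 `Cc1ccc(S(=O)(=O)n2cc(COC3=C/C(=N\c4ccc(I)cc4)c4ccccc4C3=O)nn2)cc1` gives 6310 nM
Compound 2 `Cc1ccc(S(=O)(=O)n2cc(COC3=C/C(=N\c4ccc(Br)cc4)c4ccccc4C3=O)nn2)cc1` gives 4220 nM
Compound 3 `Cc1ccc(/N=C2\C=C(OCc3cn(S(=O)(=O)c4ccc(C)cc4)nn3)C(=O)c3ccccc32)cc1` gives 5420 nM

Compound 3 cannot be ranked against the other two: a 1.2-fold lower number from compound 1 to compound 3 (0.07 log units; within the scatter) and a 1.3-fold higher number from compound 2 to compound 3 (0.11 log units; within the scatter) both stay within the scatter. The next change is compound 4 `Cc1ccc(S(=O)(=O)n2cc(COC3=C/C(=N\c4ccc(F)cc4)c4ccccc4C3=O)nn2)cc1` with fluoro in place of methyl on an aromatic carbon, para to a large group, so that 4-methylphenyl becomes 4-fluorophenyl (fluoro in place of methyl on an aromatic carbon). Those two steps and a 1.5-fold lower number from compound 1 to compound 2 (0.17 log units; within the scatter) bear on it: each exchanges one group for another on that aromatic carbon, and none leaves the scatter. Iodo, bromo and methyl therefore read alike across compound 1, compound 2 and compound 3, and none of the three goes against this. Fluoro itself has no measurement in this series, so the expectation is a carry-over from those three exchanges. In this assay the estimated step of a 1.1-fold lower number from compound 3 to compound 4 (0.04 log units; within the scatter) is expected to stay within the scatter, in no firm direction. For compound 4 the estimated value is 5000 nM with an expected range of 2700 nM to 9000 nM on this read-out.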

Compound 4, half-maximal inhibitory concentration: 7520 nM
The estimate for compound 4 lay 1.5-fold (0.18 log units) below the measured number; the range from low to high includes it.
By their numbers in this assay, from the lowest: compounds 2, 3, 1 and 4 (each within the scatter of the next).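

In this assay fluoro joins iodo, bromo and methyl as a fourth group on this aromatic carbon, para to a large group, and each of its exchanges stays within the scatter (a 1.4-fold higher number from compound 3 to compound 4 (0.14 log units; within the scatter); a 1.8-fold higher number from compound 2 to compound 4 (0.25 log units; within the scatter); a 1.2-fold higher number from compound 1 to compound 4 (0.08 log units; within the scatter)). For the compounds shown here, the earlier compounds covered only iodo, bromo and methyl; the series now also spans the 4-fluorophenyl case, and even its widest step, the one from the bromo compound, does not leave the scatter, so compound 1, compound 2, compound 3 and compound 4 cannot be put in any firm order. No supporting measurement is available to account for this flat reading.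

Whether an amine, a carboxylic acid or a longer chain on this aromatic carbon would move the number beyond the scatter remains open, since the groups shown here are only three halogens and methyl. The compounds shown also vary in this one place alone, so how changes elsewhere on the shared core would read in this assay remains open as well.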